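The source may report more compounds than this note shows. Statements on the series, on what has been measured and on what is new or still open speak of the compounds shown alone.

Of the compounds shown here, three built on one shared core have been measured in a functional assay (aorta) with Rattus norvegicus as the target; a lower number here means that less compound is needed, a higher number that more compound is needed for the effect. Compound 1 `CNC(=N)Nc1nc(-c2ccc(OC)cc2)c(-c2ccc(OC)cc2)s1` gives 1.2 uM, and compound 2 `C/N=C(/NC)Nc1nc(-c2ccc(OC)cc2)c(-c2ccc(OC)cc2)s1` gives 2.4 uM; the step of a 2.0-fold higher number from compound 1 to compound 2 (0.30 log units; within the scatter) stays within the scatter. Compound 3 `COc1ccc(-c2nc(/N=C(\N)[N+]3(C)CCCCC3)sc2-c2ccc(OC)cc2)cc1` gives 21 uM, the highest of the three numbers: it stands an 18-fold higher number from compound 1 to compound 3 (1.24 log units; beyond the scatter) and an 8.8-fold higher number from compound 2 to compound 3 (0.94 log units; beyond the scatter), both beyond the scatter, so among these three it needs the most compound for the effect.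

Compound 4 `COc1ccc(-c2nc(CNC(=O)NC(C)C)sc2-c2ccc(OC)cc2)cc1` has not yet been measured. It differs from compound 3 by a group of 8 heavy atoms (5 carbon, 2 nitrogen, 1 oxygen; no ring) in place of a group of 10 heavy atoms (7 carbon, 3 nitrogen; one six-membered non-aromatic ring with 1 hetero atom), on an aromatic carbon. The group that leaves carries a net charge and a ring; the ((isopropylcarbamoyl)amino)methyl group that enters has no net charge and no ring.

For the measured compounds named here, no measured step covers this exact change. The two steps that end at compound 3, an 18-fold higher number from compound 1 to compound 3 (1.24 log units; beyond the scatter) and an 8.8-fold higher number from compound 2 to compound 3 (0.94 log units; beyond the scatter), show that placing the charged ring group at this aromatic carbon in place of small uncharged groups went with a higher number. Exchanging it for another uncharged group is therefore expected to bring the number down, though the entering group is unlike either small group, so the size is uncertain; the step of a 2.6-fold lower number from compound 3 to compound 4 (0.42 log units; beyond the scatter) is the estimate. For compound 4 the expected value is 8 uM, within 2 uM to 40 uM.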

Compound 4, concentration for half-maximal effect: 5.7 uM
The estimate for compound 4 lay 1.4-fold (0.15 log units) above the measured number, and the stated range covers the measured number.
By their numbers in this assay, from the lowest: compounds 1 and 2 (each within the scatter of the next); then compound 4; then compound 3.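

In this assay, for the compounds shown here, exchanging the charged ring group for the ((isopropylcarbamoyl)amino)methyl group gives a 3.7-fold lower number from compound 3 to compound 4 (0.57 log units; beyond the scatter), so on this aromatic carbon the number also comes down with an uncharged group larger than the small groups of the earlier compounds. The exchange does not bring the number back to their level, however: a 2.4-fold higher number from compound 2 to compound 4 (0.38 log units; beyond the scatter) and a 4.8-fold higher number from compound 1 to compound 4 (0.68 log units; beyond the scatter) are both printed as beyond the scatter. Among these four compounds, having no net charge at this position is therefore not enough to match compound 1 or compound 2, and the entering group itself goes with a number that lies between theirs and that of compound 3.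

The net charge and the ring leave together in the step to compound 4, so the compounds shown cannot separate the two, and there is no measured evidence that explains any of these differences. Going by these compounds, how a simple amine, a carboxylic acid or a longer chain on this aromatic carbon would compare in this assay remains open.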